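Shortening the Side Chain: From Compound 3 to Compound 4

A few compounds are considered here, and "the series" means these few. Any claim that something is new, unique, unknown or untested is made for them only; others in the source may bear on it.

Three compounds share one core and differ only in the side chain of their amino-acid part. Compound 1 `CC[C@H](C)[C@H](NC(=O)CN(c1nc(Cl)nc2[nH]cnc12)C1CC1)C(=O)O` carries a sec-butyl group, and in a functional assay on the whole organism (Tail, strain ICR) with Mus musculus as the target, in the tail flick test, with a stated time of 30 min, at a dose of 25 umol/kg by the oral route (on this read-out lower numbers stand for a weaker effect and higher numbers for a stronger effect at the one dose given), compound 1 gives 30.3%. Compound 2 `O=C(O)CC[C@H](NC(=O)CN(c1nc(Cl)nc2[nH]cnc12)C1CC1)C(=O)O` carries a 2-carboxyethyl group, and in this assay compound 2 gives 26.8%. Compound 3 `NCCCC[C@H](NC(=O)CN(c1nc(Cl)nc2[nH]cnc12)C1CC1)C(=O)O` carries a 4-aminobutyl group, and in this assay compound 3 gives 31.2%. Compound 3 has the highest of the three numbers shown, but its steps from the others, a number 0.9 percentage points higher from compound 1 to compound 3 (within the scatter) and a number 4.4 percentage points higher from compound 2 to compound 3 (within the scatter), both lie within the scatter, so the three compounds cannot be told apart on these numbers.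

Compound 4 `C[C@H](NC(=O)CN(c1nc(Cl)nc2[nH]cnc12)C1CC1)C(=O)O` differs from compound 3 in one place: hydrogen in place of 3-aminopropyl on a saturated chain carbon, two bonds along the chain from an amide-type nitrogen and a carbonyl carbon. Within the data shown here, no measured pair tests exactly this change. The steps that come closest are the side-chain swaps already seen, a number 3.5 percentage points lower from compound 1 to compound 2 (within the scatter), a number 0.9 percentage points higher from compound 1 to compound 3 (within the scatter) and a number 4.4 percentage points higher from compound 2 to compound 3 (within the scatter), and each of them was within the scatter, whatever the side chain was. On that basis the expected step of a number 2.2 percentage points lower from compound 3 to compound 4 (within the scatter) is none beyond the scatter. Compound 4 is therefore estimated at 29%, with a range from 17% to 41%.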

Compound 4, a percentage reported as activity, at one dose (the size of the read-out at that dose, not a potency): 48.1%
Compound 4: middle estimate off by 19.1 percentage points, on the low side; measured number outside the range, above it.
By their numbers in this assay, from the lowest: compounds 2, 1 and 3 (each within the scatter of the next); then compound 4.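

In this assay, the side chain on the saturated chain carbon bound to an amide-type nitrogen and a carbonyl carbon turns out to matter, since the methyl of compound 4 stands clear of all three longer side chains: a number 16.9 percentage points higher from compound 3 to compound 4 (beyond the scatter), a number 21.3 percentage points higher from compound 2 to compound 4 (beyond the scatter) and a number 17.8 percentage points higher from compound 1 to compound 4 (beyond the scatter). The swaps among sec-butyl, 2-carboxyethyl and 4-aminobutyl had suggested that this position tolerated any change without effect, yet those three compounds, whether their chain ends in an amine, a carboxylic acid or plain carbon, cannot be told apart, and only the methyl compound separates from them. Nothing available explains why shortening the side chain to methyl gives this step.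

The compounds shown leave open whether methyl itself is special or whether any short side chain would do the same, which a lone hydrogen, an ethyl or a hydroxymethyl group at this carbon could test. They also leave open how the effect of compound 4 would look at other doses, as this read-out gives its size at one dose and not a potency.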